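The compounds below may be only part of what the source reports. "The series", "measured", "known", "first", "only" and "open" are said of these compounds alone.

Measured so far in a functional assay on HepG2 cells (Homo sapiens) for inhibition, read by MTT assay, with a stated time of 48 h; on this read-out higher numbers stand for weaker inhibition and lower numbers for stronger inhibition:

compound 1 `CS(=O)(=O)c1ccc(-c2nc3ccccn3c2Sc2ccccc2)cc1` — 13200 nM
compound 2 `C(=C/c1nc2ccccn2c1Sc1ccccc1)\c1ccccc1` — 8800 nM

Notes on the series. Compound 1 `CS(=O)(=O)c1ccc(-c2nc3ccccn3c2Sc2ccccc2)cc1` gives 13200 nM in this assay. Compound 2 `C(=C/c1nc2ccccn2c1Sc1ccccc1)\c1ccccc1` gives 8800 nM in this assay. The two numbers lie within the usual scatter of each other, so neither compound can be called the stronger or the weaker of the pair; both sit at the weak end of what this read-out resolves. Among the measured compounds shown here, compound 2 is not a single-point change from compound 1, so the two together give no measured step to lean on.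

Compound 3 `Clc1ccc(-c2nc3ccccn3c2Sc2ccccc2)cc1` is still to be measured. It differs from compound 1 by chloro in place of methylsulfonyl on an aromatic carbon. For the measured compounds named here, no measured step of this kind exists, so the size of the step is unknown. The expectation is a step no larger than the scatter, perhaps a small move toward a lower number, and the estimated step from compound 1 to compound 3 is a 1.5-fold lower number from compound 1 to compound 3 (0.17 log units; within the scatter). Compound 3 is therefore expected to give about 9000 nM in this assay, with a range from 3000 nM to 30000 nM.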

Compound 3, half-maximal inhibitory concentration: 13900 nM
Estimate against measurement, compound 3: 1.5-fold (0.19 log units) below; the range from low to high includes it.
By their numbers in this assay, from the lowest: compounds 2, 1 and 3 (each within the scatter of the next).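

Working notes on the series. In this assay, among the compounds shown here, the exchange of methylsulfonyl for chloro, on an aromatic carbon para to a large group, gives a 1.1-fold higher number from compound 1 to compound 3 (0.02 log units; within the scatter) and is the first measured step at this position; it lies within the scatter, so compound 1 and compound 3 cannot be told apart, and a single chlorine atom reads the same here as the larger methylsulfonyl group. The exchange of 2-phenylethenyl for 4-chlorophenyl gives a 1.6-fold higher number from compound 2 to compound 3 (0.20 log units; within the scatter) and also lies within the scatter, so that larger replacement on the shared core does not separate compound 2 from compound 3 either. No supporting measurement bears on this result, and the reason for the flat read-out stays unknown.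

Still open, on these data alone, is whether any group at this position can move the number beyond the scatter, for example an amine or a carboxylic acid in place of chloro on the same ring. The compounds shown also leave open whether the phenylthio part of the core matters, since it is the same in all three, and a pyridine ring or a longer chain there would test this.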